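Cyano for fluoro on an inactive proline amide pair

The source may report more compounds than this note shows. Statements on the series, on what has been measured and on what is new or still open speak of the compounds shown alone.

Compound 1 `NC(=O)[C@@H]1CC[C@H](c2ccc(OCc3ccc(F)cc3)cc2)N1` gives no numeric result in an assay on HEK293 cells for inhibition of sodium channel protein type 3 subunit alpha (Homo sapiens), read by electrophysiology, with a stated time of 3.5 min; a higher number here means a weaker inhibitor, a lower number a stronger inhibitor; for compound 1 the reading is a limit of the assay, > 63000 nM. Compound 1 thus stands at the limit of > 63000 nM in this assay, at which 1 of the 2 values shown sits. Compound 2 `N#Cc1cc([C@H]2CC[C@@H](C(N)=O)N2)ccc1OCc1ccccc1F` likewise returns only a limit in this assay, > 50100 nM. Compound 2 sits at the limit of > 50100 nM in this assay, at which 1 of the 2 values shown sits. For the measured compounds named here, neither of the two measured compounds shows any inhibition within the tested range, and no step between measured compounds exists from which a size or direction could be read.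

Compound 3 `N#Cc1ccc(COc2ccc([C@H]3CC[C@@H](C(N)=O)N3)cc2)cc1` differs from compound 1 by cyano in place of fluoro on an aromatic carbon of a six-membered aromatic ring of carbon only, para to a large group; cut one bond further out, 4-fluorophenyl to 4-cyanophenyl. With both measured values at limits, the series gives no ground to expect a change beyond the scatter in this assay. Compound 3 is expected to stay at or near the limit, so the step from compound 1 to compound 3 is estimated as a number no higher from compound 1 to compound 3 (the limit leaves the size open). Compound 3 is estimated at 63000 nM, with a range from 20000 nM to 200000 nM.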

Compound 3, half-maximal inhibitory concentration: > 63000 nM
Compound 3 ended at the assay's limit; the forecaster's own chance of this, stated with the estimate: 80%; the middle value sits exactly at the limit.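

Compound 1 and compound 3 both stand at limits in this assay, and the step between them, cyano in place of fluoro on an aromatic carbon, cannot be read. The compounds shown leave open whether this change has any effect on inhibition, and whether any compound in the series gives a numeric reading in this assay.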